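Chloro position on the benzoyl group in the series

The source may hold more compounds than are shown below. What is called first, only, known or untested is meant among the compounds shown, and "the series" means these compounds.

Compound 3 `O=C(Nc1ccccc1O)C1CCc2ccccc2N1C(=O)c1ccc(Cl)cc1` gives 19200 nM in a functional assay on NCI-H23 cells (Homo sapiens) for cytotoxicity, read by sulforhodamine B assay, with a stated time of 72 h (a lower number here means a stronger inhibitor of growth, a higher number a weaker inhibitor of growth), the highest of the three numbers at hand. Going by the values given here, compound 2 `O=C(Nc1ccccc1O)C1CCc2ccccc2N1C(=O)c1ccccc1` gives 3490 nM, and the step of a 5.5-fold higher number from compound 2 to compound 3 (0.74 log units; beyond the scatter) is the only single change measured so far. Compound 1 `O=C(Nc1ccccc1C(F)(F)F)C1CCc2ccccc2N1C(=O)c1cccc(Cl)c1` gives 292 nM, but it differs from compound 3 in two places, so its number cannot be tied to either change alone. Compound 4 `O=C(Nc1ccccc1O)C1CCc2ccccc2N1C(=O)c1cccc(Cl)c1` carries the change (3-chlorophenyl in place of 4-chlorophenyl on a carbonyl carbon). Among the compounds with values here, no measured step covers this move directly; the step of a 5.5-fold higher number from compound 2 to compound 3 (0.74 log units; beyond the scatter) shows only that chloro in place of hydrogen on an aromatic carbon can move the number by a modest amount. Compound 4 is therefore expected at 6000 nM, between 1500 nM and 25000 nM. The expected step is a 3.2-fold lower number from compound 3 to compound 4 (0.51 log units; beyond the scatter).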

Compound 4, concentration for 50% growth inhibition: 11600 nM
The estimate for compound 4 lay 1.9-fold (0.29 log units) below the measured number; the measured number falls inside the stated range.
By their numbers in this assay, from the lowest: compound 1; then compound 2; then compounds 4 and 3 (each within the scatter of the next).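

In this assay, 3-chlorophenyl in place of 4-chlorophenyl on a carbonyl carbon gives a 1.7-fold lower number from compound 3 to compound 4 (0.22 log units; within the scatter), so the two chloro placements are not told apart here. Chloro in place of hydrogen on an aromatic carbon gives a 3.3-fold higher number from compound 2 to compound 4 (0.52 log units; beyond the scatter), which matches the direction of a 5.5-fold higher number from compound 2 to compound 3 (0.74 log units; beyond the scatter). Hydroxy in place of trifluoromethyl on an aromatic carbon gives a 40-fold higher number from compound 1 to compound 4 (1.60 log units; beyond the scatter), the largest step here.

Nothing at hand explains these steps. Open remain an amine or methoxy in place of the chloro, and whether 4-chlorophenyl and 3-chlorophenyl also stay together with trifluoromethyl in place of hydroxy.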